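A few compounds are considered here, and "the series" means these few. Any claim that something is new, unique, unknown or untested is made for them only; others in the source may bear on it.

Measured so far:
Compound 1 `CC1=CC[C@H](C(C)(C)NC(=S)N/N=C/c2ccccc2Cl)CC1` gives > 100000 nM
Compound 2 `CC1=CC[C@H](C(C)(C)NC(=S)N/N=C/c2cccc(Cl)c2)CC1` gives > 100000 nM
Compound 3 `CC1=CC[C@H](C(C)(C)NC(=S)N/N=C/c2ccccc2[N+](=O)[O-])CC1` gives > 100000 nM

All three were tested in a functional assay on NCI/ADR-RES cells (Homo sapiens) for inhibition, read by sulforhodamine B assay, with a stated time of 48 h; a lower number here means a stronger inhibitor of growth, a higher number a weaker inhibitor of growth. For compound 1 the value > 100000 nM is a limit of the assay, not a number. For compound 2 the value > 100000 nM is likewise a limit. For compound 3 the value > 100000 nM is likewise a limit. Compound 2 differs from compound 1 by 3-chlorophenyl in place of 2-chlorophenyl on a carbon with a double bond to nitrogen, and the step between them is a step that the two limits leave unreadable from compound 1 to compound 2. Compound 3 differs from compound 1 by nitro in place of chloro on an aromatic carbon; the step here is a step that the two limits leave unreadable from compound 1 to compound 3. Every value sits at the limit of > 100000 nM in this assay, at which 3 of the 3 values shown sit.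

Compound 4 `CC1=CC[C@H](C(C)(C)NC(=S)N/N=C/c2cccc([N+](=O)[O-])c2)CC1` is not yet measured. It differs from compound 2 by nitro in place of chloro on an aromatic carbon. This is the same kind of change as from compound 1 to compound 3, but not the same: in compound 1 the replaced group sits ortho to a large group, in compound 2 meta to a large group.

The step from compound 2 to compound 4 is expected to be a step that the limit leaves unreadable from compound 2 to compound 4, resting on the earlier step that the two limits leave unreadable from compound 1 to compound 3 and on (the limit of > 100000 nM in this assay, at which 3 of the 3 values shown sit). Compound 4 is estimated at 150000 nM, probably again a limit, between 60000 nM and 500000 nM.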

Compound 4, concentration for total growth inhibition: > 100000 nM
Compound 4: a limit, no number; the forecaster's own chance of this, stated with the estimate: 85%; the middle value lies beyond the limit too.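

Compound 2 and compound 4 each reach only a limit and not a number, so the step between them cannot be read, and neither can any other step among these compounds: the limit of > 100000 nM in this assay, at which 4 of the 4 values shown sit.

The compounds shown leave open how strongly any of them inhibits growth in this assay, and whether swapping chloro for nitro changes that at all.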